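The source may report more compounds than this note shows. Statements on the series, on what has been measured and on what is new or still open speak of the compounds shown alone.

Measured compounds:
Compound 1, `N#CC1=C(NCC(=O)N2CCOCC2)N(c2ccccc2)C(=O)N2CCCCC(N3CCCC3)C12`: 43.9%
Compound 2, `N#CC1=C(NCN2CCCC2)N(c2ccccc2)C(=O)N2CCCCC(N3CCCC3)C12`: 22.9%
Compound 3, `N#CC1=C(/N=C/Nc2ccc([N+](=O)[O-])cc2)N(c2ccccc2)C(=O)N2CCCCC(N3CCCC3)C12`: 32.1%

In a functional assay on the whole organism (strain albino) for inhibition, with Rattus norvegicus as the target, read by paw edema, with a stated time of 1 h, at a dose of 20 mmol/kg by the intraperitoneal route (on this read-out higher numbers stand for more inhibition at the one dose given (going by the name of the read-out) and lower numbers for less inhibition), compound 3 stands second highest of the three numbers: its nearest neighbour is compound 2, a gap that lies within the scatter, while compound 1 sits higher by a step that lies beyond it, a number 11.8 percentage points lower from compound 1 to compound 3 (beyond the scatter).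

Compound 4, `N#CC1=C(NCN2CCCCC2)N(c2ccccc2)C(=O)N2CCCCC(N3CCCC3)C12`, has not yet been measured. It differs from compound 3 in one place: a group of 8 heavy atoms (6 carbon, 2 nitrogen; one six-membered non-aromatic ring with 1 hetero atom) in place of a group of 12 heavy atoms (7 carbon, 3 nitrogen, 2 oxygen; one six-membered aromatic ring of carbon only), on a double-bonded ring carbon. The group that enters closely resembles the group on compound 2, differing only in the size of the non-aromatic ring. Within the data shown here, two measured steps bear on this. The step of a number 9.2 percentage points higher from compound 2 to compound 3 (within the scatter) shows that moving from a pyrrolidinylmethylamino group to the larger group of compound 3 changed the read-out only within the scatter. The step of a number 21 percentage points lower from compound 1 to compound 2 (beyond the scatter) shows that the morpholinylcarbonyl group of compound 1 gave a clearly higher number than the pyrrolidinyl group of compound 2.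

Compound 4 is therefore expected to fall near compound 2, a change of a number 6.1 percentage points lower from compound 3 to compound 4 (within the scatter) in this assay, at or within the scatter. The estimate for compound 4 is 26%, ranging from 14% to 40%.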

Compound 4, a percentage reported as inhibition, in the whole organism at one dose (the size of the read-out at that dose, not a potency): 29.7%
The estimate for compound 4 lay 3.7 percentage points below the measured number, within the range that was stated.
By their numbers in this assay, from the lowest: compounds 2, 4 and 3 (each within the scatter of the next); then compound 1.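

In this assay, among these compounds, piperidin-1-yl in place of pyrrolidin-1-yl on the saturated chain carbon bound to an amine nitrogen gives a number 6.8 percentage points higher from compound 2 to compound 4 (within the scatter), so the first comparison of these two rings at this position does not tell them apart. The ((piperidin-1-yl)methyl)amino group on the double-bonded ring carbon gives a number 2.4 percentage points lower from compound 3 to compound 4 (within the scatter) and, against the group of compound 1, a number 14.2 percentage points lower from compound 1 to compound 4 (beyond the scatter), so the piperidine compound too stays clearly apart from compound 1. No measurement is available that explains these results.

The compounds shown do not separate the part played by the carbonyl in compound 1 from that of its morpholine ring, which a morpholin-4-yl group directly on the chain carbon could address. From the compounds shown here alone, how an azepan-1-yl ring or an open-chain dimethylamino group would read at that carbon also stays open.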